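From 4-Methoxyphenyl to Methyl at the Ring Nitrogen

The compounds below may be only part of what the source reports. "The series", "measured", "known", "first", "only" and "open" are said of these compounds alone.

Compound 1 `COc1cc(N)c(Cl)cc1NC(=O)C1CCN(Cc2ccccc2Cl)CC1`: in a functional assay on the whole organism for antagonist activity, with Mus musculus as the target (a higher number here means that more compound is needed for the effect, a lower number that less compound is needed), compound 1 reaches only the assay limit > 4 mg/kg.
Compound 2 `CCOc1ccc(CN2CCC(C(=O)Nc3cc(Cl)c(N)cc3OC)CC2)cc1`: in this assay compound 2 gives 6.3 mg/kg.
Compound 3 `COc1ccc(CN2CCC(C(=O)Nc3cc(Cl)c(N)cc3OC)CC2)cc1`: in this assay compound 3 gives 0.9 mg/kg.

Compound 3 holds the lowest of the two numbers, and the nearest is compound 2, separated by the step of a 7.0-fold lower number from compound 2 to compound 3 (0.85 log units; beyond the scatter). Compound 4 `CCN1CCC(C(=O)Nc2cc(Cl)c(N)cc2OC)CC1` differs from compound 3 by methyl in place of 4-methoxyphenyl on a saturated chain carbon bound to an amine nitrogen in a ring. For the measured compounds named here, no measured step removes the whole aryl; the closest comparison is an at least 4.4-fold lower number from compound 1 to compound 3 (0.64 log units; beyond the scatter), which only exchanges one aryl for another. Because an at least 4.4-fold lower number from compound 1 to compound 3 (0.64 log units; beyond the scatter) and a 7.0-fold lower number from compound 2 to compound 3 (0.85 log units; beyond the scatter) already move the number beyond the scatter for changes on the aryl alone, compound 4 is expected to give a higher number, a step of a 5.6-fold higher number from compound 3 to compound 4 (0.74 log units; beyond the scatter). Compound 4 is estimated at 5 mg/kg, between 1.5 mg/kg and 20 mg/kg.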

Compound 4, dose for half-maximal effect: > 10 mg/kg
Compound 4: a limit, no number; the forecaster's own chance of this, stated with the estimate: 30%; middle value at least 2.0-fold (0.30 log units) from the limit.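

Compound 4 reaches no number, only an assay limit: the limit of > 10 mg/kg in this assay, at which 1 of the 4 values shown sits. Removing the whole aryl at this position, methyl replacing 4-methoxyphenyl, is an at least 11-fold higher number from compound 3 to compound 4 (1.04 log units; beyond the scatter), so the low number of compound 3 in this assay is lost with the aryl, which the aryl-for-aryl steps could not show. Against 4-ethoxyphenyl the step is an at least 1.5-fold higher number from compound 2 to compound 4 (0.20 log units; that floor lies within the scatter), so compound 2 need not differ from compound 4, and the step from compound 1 to compound 4 cannot be read.

From the compounds shown here alone, the actual value of compound 4 stays unknown. Going by these compounds, whether an unsubstituted phenyl or a 4-hydroxyphenyl at this place would keep the low number also remains open.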